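The compounds below may be only part of what the source reports. "The series", "measured", "known", "first", "only" and "open" are said of these compounds alone.

Measured so far:
- Compound 1, `CCCCCCCC/C=C/c1cc2cn([C@H]3C[C@H](O)[C@@H](CO)O3)c(=O)nc2o1`: >= 120000 nM
- Compound 2, `CCCC#Cc1ccc(-c2cc3cn([C@H]4C[C@H](O)[C@@H](CO)O4)c(=O)nc3o2)cn1`: >= 100000 nM
- Compound 3, `CCCCCc1ccc(-c2cc3cn([C@H]4C[C@H](O)[C@@H](CO)O4)c(=O)nc3o2)cc1`: > 1300 nM

All three share a bicyclic core carrying a sugar-like ring, and differ in the side arm that hangs off it. They were tested in an ADME assay on HEL cells (Homo sapiens) for cytotoxicity, with a stated time of 3 days; on this read-out higher numbers stand for lower toxicity in this test and lower numbers for higher toxicity in this test. For compound 1 the value of >= 120000 nM is a limit of the test rather than a number, as the limit of >= 120000 nM in this assay, at which 1 of the 3 values shown sits, records. For compound 2 the value of >= 100000 nM is likewise a limit, as the limit of >= 100000 nM in this assay, at which 1 of the 3 values shown sits, records. For compound 3 the value of > 1300 nM is also a limit, as the limit of > 1300 nM in this assay, at which 1 of the 3 values shown sits, records; it was simply tested up to a lower concentration, so its number says nothing about where it would sit relative to the others. Going by the values given here, compound 2 therefore stands at a limit, as do the other two values shown, and no compound can be ranked against another here.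

Compound 4, `CCCCCCc1ccc(-c2cc3cn([C@H]4C[C@H](O)[C@@H](CO)O4)c(=O)nc3o2)cn1`, is still to be tested. It differs from compound 2 only by hexyl in place of pent-1-yn-1-yl on an aromatic carbon. Because compound 2 already sits at >= 100000 nM, no direction of change can be read from the data, and a step beyond the scatter is not expected. Compound 4 is estimated at 100000 nM, between 20000 nM and 300000 nM, so that the expected step from a number no higher from compound 2 to compound 4 (the limit leaves the size open) is essentially none.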

Compound 4, minimum cytotoxic concentration: 100000 nM
The estimate for compound 4 equals the measured number at the digits printed; the range from low to high includes it.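

In this assay, compound 4 gives 100000 nM, the first value among the compounds shown that is an actual number and not a limit of the test. Hexyl in place of pent-1-yn-1-yl on this aromatic carbon, next to the ring nitrogen, gives a number no higher from compound 2 to compound 4 (the limit leaves the size open), so a chain without the triple bond can stand at this place and still give a high number, which means low toxicity in this test. On these data alone, the size of that step stays unknown because compound 2 sits at a limit of the test: the limit of >= 100000 nM in this assay, at which 1 of the 4 values shown sits.

As far as these compounds go, how far compound 2 truly lies from compound 4 therefore remains open, and with it whether the triple bond changes the read-out at all. Also open, from the compounds shown here alone, is how the read-out would respond at this same carbon to a much shorter chain such as methyl, to a longer chain such as decyl, or to a chain ending in an amine or a carboxylic acid.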